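Valine to methoxyalanine in an anticonvulsant amide series

A few compounds are considered here, and "the series" means these few. Any claim that something is new, unique, unknown or untested is made for them only; others in the source may bear on it.

Compound 1 `CC(C)[C@@H](N)C(=O)NCc1ccc(COc2cccc(F)c2)cc1` carries an isopropyl group on the saturated chain carbon bound to an amine nitrogen and a carbonyl carbon. In a functional assay on the whole organism (strain NMRI) with Mus musculus as the target, with a stated time of 30 min (a lower number here means that less compound is needed, a higher number that more compound is needed for the effect), compound 1 gives > 110 mg/kg, which is a limit of the assay and not a number. Compound 2 `CC(C)[C@@H](N)C(=O)NCc1ccc(OCc2cccc(F)c2)cc1` gives in this assay > 110 mg/kg, again a limit rather than a number. Compound 1 thus stands at the limit, and the other value shown sits there as well, as the limit of > 110 mg/kg in this assay, at which 2 of the 2 values shown sit, records. Compound 3 `COC[C@@H](N)C(=O)NCc1ccc(COc2cccc(F)c2)cc1` differs from compound 1 in one place (methoxymethyl in place of isopropyl on a saturated chain carbon bound to an amine nitrogen and a carbonyl carbon). Among the measured compounds shown here, no measured step of this kind is available, so the expectation rests only on the two limits. From compound 1 to compound 3 the expected step is a step that the limit leaves unreadable from compound 1 to compound 3, a step of no size beyond the usual scatter. Compound 3 is expected to give about 150 mg/kg, in the range 60 mg/kg to 400 mg/kg, most likely reported again only as a limit.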

Compound 3, dose for half-maximal effect: 58 mg/kg
Compound 3: the middle estimate sits 2.6-fold (0.41 log units) above what was measured; the whole stated range lies above it.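

At this position the change does what neither earlier compound could show: with methoxymethyl in place of isopropyl on the saturated chain carbon, compound 3 gives a real number in this assay, 58 mg/kg. The change amounts to an at least 1.8-fold lower number from compound 1 to compound 3 (0.27 log units; that floor lies within the scatter). Going by these compounds, that figure is only a floor, and the true size of the step stays unknown because compound 1 gives no number, only a limit: the limit of > 110 mg/kg in this assay, at which 2 of the 3 values shown sit.

The compounds shown leave open whether hydroxymethyl or a longer chain such as ethoxymethyl on this carbon would also give a number in this assay. They also leave open whether methoxymethyl would do the same on the core of compound 2.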